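Swapping 2-fluorophenyl for pyridin-2-yl in compound 2

A few compounds are considered here, and "the series" means these few. Any claim that something is new, unique, unknown or untested is made for them only; others in the source may bear on it.

Compound 1 `CC(=O)N1N=C(c2ccc3ccccc3c2)OC1c1ccccc1`: 2.11 ug/mL
Compound 2 `CC(=O)N1N=C(c2ccc3ccccc3c2)OC1c1ccccc1F`: 3.36 ug/mL

Going by the values given here, in a functional assay on HepG2 cells (Homo sapiens) for antiproliferative activity, read by MTT assay, with a stated time of 48 h (a lower number here means a stronger inhibitor, a higher number a weaker inhibitor), compound 2 stands at 3.36 ug/mL, within the scatter of compound 1, its only neighbour. Compound 3 `CC(=O)N1N=C(c2ccc3ccccc3c2)OC1c1ccccn1` has not been measured. It has pyridin-2-yl in place of 2-fluorophenyl on a saturated ring carbon. Among the compounds with values here, the only measured step touches that same substituent, and it is small: a 1.6-fold higher number from compound 1 to compound 2 (0.20 log units; within the scatter). Within the data shown here, no measured compound has a hetero atom in this ring, so the evidence is thin, and no step beyond the scatter is expected in this assay. The expected step is a 1.1-fold lower number from compound 2 to compound 3 (0.05 log units; within the scatter). Compound 3 is expected at 3 ug/mL, with an estimated range of 1 ug/mL to 9 ug/mL.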

Compound 3, half-maximal inhibitory concentration: 5.26 ug/mL
For compound 3 the middle estimate is 1.8-fold (0.24 log units) below the measured one, and the stated range covers the measured number.
By their numbers in this assay, from the lowest: compounds 1, 2 and 3 (each within the scatter of the next, the first and the last beyond it).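

Going by these compounds alone, putting a nitrogen into this aromatic ring gives a 1.6-fold higher number from compound 2 to compound 3 (0.19 log units; within the scatter) in this assay and is the first change on this saturated ring carbon to leave the scatter, though only when pyridin-2-yl is set against phenyl, which gives a 2.5-fold higher number from compound 1 to compound 3 (0.40 log units; beyond the scatter) and remains a modest step. Nothing measured here accounts for this shift. Going by these compounds, whether pyridin-4-yl would behave like pyridin-2-yl remains open, as does the effect of an amine or a carboxylic acid on this ring.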